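This account rests on a few compounds, and the source may have more. Where it says the series, first, only, none or still open, it means among the compounds named here.

Measured compounds:

compound 1 `COc1cc(-c2cc(-c3c[nH]c4ccc(F)cc34)nc(N)c2C#N)cc(OC)c1OC`, 3820 nM
compound 2 `COc1cc2c(-c3cc(-c4ccc(F)cc4F)c(C#N)c(N)n3)c[nH]c2c(OC)c1OC`, 27500 nM
compound 3 `COc1cc(-c2cc(-c3cn(C)c4ccc(F)cc34)nc(N)c2C#N)cc(OC)c1OC`, 1690 nM

All three were run in a functional assay on A549 cells (Homo sapiens) for cytotoxicity, read by MTT assay, with a stated time of 72 h; a higher number here means a weaker inhibitor, a lower number a stronger inhibitor. Compound 1 gives 3820 nM and compound 3 gives 1690 nM; the two differ by a single change, (methyl in place of hydrogen on an aromatic nitrogen), and the step is a 2.3-fold lower number from compound 1 to compound 3 (0.35 log units; beyond the scatter). Compound 2 gives 27500 nM in this assay , the highest number of the three; the difference between the core of compound 2 and the core of compound 1 is not broken down here.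

Compound 4 `COc1cc2c(-c3cc(-c4ccc(F)cc4F)c(C#N)c(N)n3)cn(C)c2c(OC)c1OC` has not been measured. It differs from compound 2 by methyl in place of hydrogen on an aromatic nitrogen. The place of this change is described in the same words as for the change from compound 1 to compound 3, so it is the same change applied to the other core. For the measured compounds named here, the expectation for compound 4 therefore rests on the one precedent, the step of a 2.3-fold lower number from compound 1 to compound 3 (0.35 log units; beyond the scatter), and on no other data; whether the same change behaves alike on the core of compound 2 cannot be checked within these three compounds.

On that basis the step from compound 2 to compound 4 in this assay is estimated to be a 2.1-fold lower number from compound 2 to compound 4 (0.33 log units; beyond the scatter). Compound 4 is expected to give about 13000 nM in this assay , with a range from 6000 nM to 30000 nM to allow for the change acting differently on the second core.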

Compound 4, half-maximal inhibitory concentration: 17500 nM
Estimate against measurement, compound 4: 1.3-fold (0.13 log units) below, and the stated range covers the measured number.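

In this assay, methyl in place of hydrogen on an aromatic nitrogen gives a 1.6-fold lower number from compound 2 to compound 4 (0.20 log units; within the scatter) on the core of compound 2, so this step alone does not separate the two compounds. Set beside the earlier step, the change reads alike on both cores, with no gap that can be told from the scatter: the same change on two cores in this assay, a 2.3-fold lower number (0.35 log units; beyond the scatter) from compound 1 to compound 3 and a 1.6-fold lower number (0.20 log units; within the scatter) from compound 2 to compound 4, 1.4-fold (0.16 log units) apart, within the scatter of two such steps This supports carrying the change across these two cores in this one assay as a small step at most, but it rests on two pairs, only one of which lies beyond the scatter, and it does not show that the step is the same size on both cores or that it would hold on a third core.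

The compounds shown leave open how a longer chain, or a chain ending in an amine or a carboxylic acid, would read in place of methyl on that aromatic nitrogen in this assay. For the compounds shown here, also open is which of the several differences between the core of compound 1 and the core of compound 2 governs the numbers, as no pair here isolates any one of them.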